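The source may report more compounds than this note shows. Statements on the series, on what has been measured and on what is new or still open speak of the compounds shown alone.

Of the compounds shown here, three that share one core have been measured in an assay for inhibition of serine/threonine-protein kinase Sgk1 (Homo sapiens), with stated times of 30 min and 60 min, in the presence of a further agent that is not named here; a higher number here means a weaker inhibitor, a lower number a stronger inhibitor. Compound 1 has the structure `O=C(N[C@@H]1CCNC1)c1cc(-c2ccc(NS(=O)(=O)c3cccc(Cl)c3Cl)cc2)nc2[nH]ncc12`. In this assay compound 1 gives < 1 nM, which is a limit of the assay rather than a number. Compound 2, `CN1CCC(NC(=O)c2cc(-c3ccc(NS(=O)(=O)c4cccc(Cl)c4Cl)cc3)nc3[nH]ncc23)C1`, carries a 1-methylpyrrolidin-3-yl group on the amide-type nitrogen. In this assay compound 2 gives < 1 nM, again a limit. Compound 3, `NCCNC(=O)c1cc(-c2ccc(NS(=O)(=O)c3cccc(Cl)c3Cl)cc2)nc2[nH]ncc12`, carries a 2-aminoethyl group at that same place. In this assay compound 3 gives < 1 nM, also a limit. Because all three sit at the limit of < 1 nM in this assay, at which 3 of the 3 values shown sit, the steps a step that the two limits leave unreadable from compound 1 to compound 2, a step that the two limits leave unreadable from compound 1 to compound 3 and a step that the two limits leave unreadable from compound 2 to compound 3 cannot be sized; each could be a change in either direction or none at all. Compound 4, `CN1CC(NC(=O)c2cc(-c3ccc(NS(=O)(=O)c4cccc(Cl)c4Cl)cc3)nc3[nH]ncc23)C1`, is not yet measured and differs from compound 3 by 1-methylazetidin-3-yl in place of 2-aminoethyl on an amide-type nitrogen. The measured steps give no direction, so a step no larger than the scatter is expected, a step that the limit leaves unreadable from compound 3 to compound 4, with a fair chance that only a limit is reported. Compound 4 is therefore estimated at 0.7 nM, between 0.2 nM and 2.5 nM.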

Compound 4, half-maximal inhibitory concentration: < 1 nM
Compound 4: only a limit was reported (the forecaster's own chance of this, stated with the estimate: 70%); the middle value lies beyond the limit too.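

No step from compound 1, compound 2 or compound 3 to compound 4 can be read, because all four values are limits rather than numbers: the limit of < 1 nM in this assay, at which 4 of the 4 values shown sit.

The compounds shown leave open whether the groups on the amide-type nitrogen differ at all in this assay, and by how much.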